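Furan-2-yl in place of the fluoromethoxyphenyl on the shared core

The source may report more compounds than this note shows. Statements on the series, on what has been measured and on what is new or still open speak of the compounds shown alone.

Compound 1 `COc1ccc(-c2nc3cccc(-c4cc(OC)c(OC)c(OC)c4)c3o2)cc1F` is known in a functional assay on MCF7 cells (Homo sapiens) for antiproliferative activity, read by MTT assay, with a stated time of 48 h (a lower number here means a stronger inhibitor, a higher number a weaker inhibitor), only by a limit: in this assay compound 1 gives > 25000 nM, a limit of the assay rather than a number. Compound 2 `COc1cc(-c2nc3cccc(-c4cc(OC)c(OC)c(OC)c4)c3o2)ccc1O` likewise stops at a limit, giving > 25000 nM in this assay. Within the data shown here, the one measured step, a step that the two limits leave unreadable from compound 1 to compound 2, is thus of unreadable size, since (the limit of > 25000 nM in this assay, at which 2 of the 2 values shown sit). Compound 3 `COc1cc(-c2cccc3nc(-c4ccco4)oc23)cc(OC)c1OC` carries furan-2-yl in place of 3-fluoro-4-methoxyphenyl on an aromatic carbon. Among the measured compounds shown here, no measured step bears on this change. The expected step of a number no higher from compound 1 to compound 3 (the limit leaves the size open) has no direction that the data support, and compound 3 is expected most likely to stop at a limit too. The estimate for compound 3 is 25000 nM, within 5000 nM to 50000 nM.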

Compound 3, half-maximal inhibitory concentration: > 25000 nM
Compound 3 ended at the assay's limit; the forecaster's own chance of this, stated with the estimate: 70%; the middle value lies on the limit itself.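

No step from compound 1 or compound 2 to compound 3 can be read, since all three compounds end at the same limit: the limit of > 25000 nM in this assay, at which 3 of the 3 values shown sit.

The compounds shown leave open whether any group at this place on the shared core gives a measurable value in this assay.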